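Sulfonyl substituent change in the phenoxyacetic acid series

The compounds below may be only part of what the source reports. "The series", "measured", "known", "first", "only" and "open" are said of these compounds alone.

Compound 1 `Cc1ccc(S(=O)(=O)Cc2ccccc2)cc1C#Cc1cc(Cl)ccc1OCC(=O)O` gives 5 nM in an assay on CHO cells for displacement of a labelled ligand from prostaglandin D2 receptor 2 (Homo sapiens), read by scintillation counting; a higher number here means a weaker inhibitor, a lower number a stronger inhibitor. Among the measured compounds shown here, compound 2 `Cc1ccc(S(=O)(=O)N(C)CCCN(C)C)cc1C#Cc1cc(Cl)ccc1OCC(=O)O` gives 287 nM in this assay, the highest of the two numbers so far; the only measured step is a 57-fold higher number from compound 1 to compound 2 (1.76 log units; beyond the scatter). Compound 3 `CCN(CC)S(=O)(=O)c1ccc(C)c(C#Cc2cc(Cl)ccc2OCC(=O)O)c1` carries diethylamino in place of (3-(dimethylamino)propyl)(methyl)amino on a sulfonyl sulfur. For the measured compounds named here, no measured step covers this exact change; the single step to compound 2 shows that a change on the sulfonyl sulfur can move this assay by a large amount, and compound 3 keeps the nitrogen on the sulfonyl sulfur of compound 2 while losing the acceptor that entered there. A modest move back toward compound 1 is expected, a 2.9-fold lower number from compound 2 to compound 3 (0.46 log units; beyond the scatter). Compound 3 is estimated at 100 nM, range 30 nM to 400 nM.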

Compound 3, inhibition constant: 3.4 nM
Beside the measured number, compound 3's estimate is 29-fold (1.47 log units) above it, outside the stated range (below it).
By their numbers in this assay, from the lowest: compounds 3 and 1 (each within the scatter of the next); then compound 2.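

Diethylamino on a sulfonyl sulfur gives an 84-fold lower number from compound 2 to compound 3 (1.93 log units; beyond the scatter) in this assay, so a nitrogen at this place does not by itself bring the high number of compound 2, which goes with the (3-(dimethylamino)propyl)(methyl)amino group. Benzyl and diethylamino show no separation here, with a 1.5-fold lower number from compound 1 to compound 3 (0.17 log units; within the scatter). Nothing available explains the large step.

Open, on these data alone, is whether the dimethylamino group or the chain carrying it goes with the high number. A propyl chain ending in a methoxy group, or a piperidine on the sulfonyl sulfur, would help separate the two.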